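A few compounds are considered here, and "the series" means these few. Any claim that something is new, unique, unknown or untested is made for them only; others in the source may bear on it.

Compound 1, `COC(=O)/C(=C\c1ccc(O)cc1)Sc1ccnc2cc(Cl)ccc12`, in a functional assay on HL-60 cells (Homo sapiens) for cytotoxicity, read by MTT assay, with a stated time of 24 h; a lower number here means a stronger inhibitor, a higher number a weaker inhibitor: 4310 nM
Compound 2, `COC(=O)/C(=C\c1ccc(OC(=O)c2ccccc2OC)cc1)Sc1ccnc2cc(Cl)ccc12`, in this assay: 44500 nM

Compound 2 gives the highest of the two numbers recorded here; the nearest is compound 1, and the step of a 10-fold higher number from compound 1 to compound 2 (1.01 log units; beyond the scatter) lies beyond the scatter, so compound 2 is the weaker of the two. The unmeasured compound 3 is `COC(=O)/C(=C\c1ccc(OC(=O)c2c(OC)cccc2OC)cc1)Sc1ccnc2cc(Cl)ccc12`. Compound 3 differs from compound 2 by methoxy in place of hydrogen on an aromatic carbon, the 2-methoxyphenyl becoming 2,6-dimethoxyphenyl. For the measured compounds named here, no measured step adds a methoxy to this ring; the only step available, a 10-fold higher number from compound 1 to compound 2 (1.01 log units; beyond the scatter), concerns the whole (2-methoxyphenyl)carbonyl entering and does not test a second methoxy. With no direct guide, the change is expected to leave the number near that of compound 2, and the step of a 1.1-fold higher number from compound 2 to compound 3 (0.05 log units; within the scatter) is estimated to stay within the scatter. For compound 3 the expected value in this assay is 50000 nM, with an estimated range from 15000 nM to 160000 nM.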

Compound 3, half-maximal inhibitory concentration: 37200 nM
Estimate against measurement, compound 3: 1.3-fold (0.13 log units) above; the measured number falls inside the stated range.
By their numbers in this assay, from the lowest: compound 1; then compounds 3 and 2 (each within the scatter of the next).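

In this assay, setting the 2,6-dimethoxyphenyl against the 2-methoxyphenyl gives a 1.2-fold lower number from compound 2 to compound 3 (0.08 log units; within the scatter) and so adds nothing beyond the scatter, which means that this methoxy in place of hydrogen, on the aromatic carbon ortho to a large group and meta to a methoxy group, does not separate the two numbers. The (2,6-dimethoxyphenyl)carbonyl in place of hydrogen on the oxygen gives an 8.6-fold higher number from compound 1 to compound 3 (0.94 log units; beyond the scatter) in this assay and thus shows a higher number for a second acyl group on that oxygen, in the same direction as a 10-fold higher number from compound 1 to compound 2 (1.01 log units; beyond the scatter) for the (2-methoxyphenyl)carbonyl. Nothing measured alongside these numbers accounts for either result.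

The compounds shown leave open whether a benzoyl carrying no methoxy at all, or one with a hydroxy group or an amine on this ring in place of a methoxy, would give a number close to these. They also leave open whether a small acetyl on the same oxygen would give a higher number than the free hydroxy group, or whether that step appears only with the larger aromatic carbonyl groups.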